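This account rests on a few compounds, and the source may have more. Where it says the series, first, only, none or still open, it means among the compounds named here.

In an ADME assay on Caco-2 cells (Homo sapiens) for permeability, read by LC-MS, with a stated time of 2 h, at pH 7.4, tested at 10 uM (a lower number here means that the compound crosses the layer more slowly, a higher number that the compound crosses the layer faster), compound 2 (`C[C@H]1Cn2c(nnc2C(F)(F)F)CN1C(=O)c1cccc(Cc2n[nH]c(=O)c3c2CCCC3)c1`) reads 0.9 10^-6 cm/s and sits at the low end of the three numbers in hand. Compound 1 (`O=C(c1cccc(C(F)(F)c2n[nH]c(=O)c3c2CCCC3)c1)N1CCn2c(nnc2C(F)(F)F)C1`) reads 1.3 10^-6 cm/s and lies within the scatter of compound 2, so the two cannot be ordered. Compound 3 (`C[C@H]1Cn2c(Br)nnc2CN1C(=O)c1cccc(C(F)(F)c2n[nH]c(=O)c3ccccc23)c1`) reads 12.1 10^-6 cm/s and stands clearly apart on the high side, beyond the scatter from compound 2. Neither compound 1 nor compound 3 differs from compound 2 in one place only, so no measured single change is available as a guide.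

Compound 4 (`C[C@@H]1Cn2c(nnc2C(F)(F)F)CN1C(=O)c1cccc(Cc2n[nH]c(=O)c3c2CCCC3)c1`) has no number yet. Its relation to compound 2 is this: the two compounds have the same atoms and bonds and differ only in configuration as drawn: 1 of 1 stereo elements differ; a stereocentre at a saturated ring carbon is drawn S in compound 2 and R in compound 4 and a stereocentre at a saturated ring carbon is drawn S in compound 2 and R in compound 4. The two compounds have the same atoms and bonds and differ only in configuration as drawn. Going by the values given here, no pair measured so far tests such a change, so the expectation in this assay is of no step beyond the scatter and no set direction. It rests on compound 2 at 0.9 10^-6 cm/s as the closest reference. The expected size is a 1.1-fold higher number from compound 2 to compound 4 (0.05 log units; within the scatter) and that stays within the scatter. Compound 4 is estimated at 1 10^-6 cm/s with 0.5 10^-6 cm/s to 2.2 10^-6 cm/s as the expected range.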

Compound 4, apparent permeability: 0.3 10^-6 cm/s
The estimate for compound 4 lay 3.3-fold (0.52 log units) above the measured number; measured number outside the range, below it.
By their numbers in this assay, from the lowest: compound 4; then compounds 2 and 1 (each within the scatter of the next); then compound 3.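

The stereocentre at a saturated ring carbon is not a silent position in this assay: going from S to R gives a 3.0-fold lower number from compound 2 to compound 4 (0.48 log units; beyond the scatter). Going by these compounds alone, this is the first single change with a measured step, as the earlier compounds all differed from one another in more than one place, and it shows that configuration alone can shift the number beyond the scatter, with S the higher of the two forms on this core. With no atom or bond entering or leaving, the step can be assigned only to the inverted stereocentre: the fact that compounds 2 and 4 differ only in the configuration as drawn

On these data alone, this rests on one pair, so it remains open whether the same inversion moves the number in the same direction and by a similar size on the core of compound 3 or on other cores of the series. Also open, as far as these compounds go, is how the number responds when the group at this saturated ring carbon is replaced, for example by an ethyl group or a longer chain bearing an amine, in either configuration.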